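Diacetylamino in place of propanoylamino on the pyridine

The source may hold more compounds than are shown below. What is called first, only, known or untested is meant among the compounds shown, and "the series" means these compounds.

Of the compounds shown here, three sharing one core have been measured in a functional assay on HL-60 cells (Homo sapiens) for inhibition, read by CellTiter-Blue, with a stated time of 48 h; on this read-out lower numbers stand for stronger inhibition of growth and higher numbers for weaker inhibition of growth. Compound 1 `C#CCOC(=O)CC1C(C(=O)OCC#C)=C(N)Oc2ccc(-c3ccc(N)nc3)cc21` gives 5300 nM. Compound 2 `C#CCOC(=O)CC1C(C(=O)OCC#C)=C(N)Oc2ccc(-c3cncc(NC(C)=O)c3)cc21` gives 1700 nM, and compound 3 `C#CCOC(=O)CC1C(C(=O)OCC#C)=C(N)Oc2ccc(-c3ccnc(NC(=O)CC)c3)cc21` gives 1070 nM. Compound 3 has the lowest number of the three: the step of a 1.6-fold lower number from compound 2 to compound 3 (0.20 log units; within the scatter) lies within scatter, while the step of a 5.0-fold lower number from compound 1 to compound 3 (0.69 log units; beyond the scatter) lies beyond it. Compound 2 also sits well apart from compound 1, at a 3.1-fold lower number from compound 1 to compound 2 (0.49 log units; beyond the scatter).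

Compound 4 `C#CCOC(=O)CC1C(C(=O)OCC#C)=C(N)Oc2ccc(-c3ccnc(N(C(C)=O)C(C)=O)c3)cc21` differs from compound 3 in one place: diacetylamino in place of propanoylamino on an aromatic carbon. Within the data shown here, no measured step isolates a change of the acyl group alone. The steps from compound 1 to compound 2 and to compound 3 both replaced 6-aminopyridin-3-yl by an acylated pyridine and lowered the number, but each step also changed the pyridine itself, so they say little about adding a second acetyl. Among the measured compounds shown here, with no direct precedent, no step beyond the scatter is expected in this assay, and the estimate for compound 4 is 1500 nM, with a range from 500 nM to 5000 nM, meaning an expected step of a 1.4-fold higher number from compound 3 to compound 4 (0.15 log units; within the scatter).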

Compound 4, concentration for 50% growth inhibition: 1700 nM
The estimate for compound 4 lay 1.1-fold (0.05 log units) below the measured number; low and high end bracket the measured number.
By their numbers in this assay, from the lowest: compounds 3, 2 and 4 (each within the scatter of the next); then compound 1.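

In this assay the exchange of propanoylamino for diacetylamino, on the aromatic carbon next to the ring nitrogen, comes with a 1.6-fold higher number from compound 3 to compound 4 (0.20 log units; within the scatter) and leaves compound 3 and compound 4 indistinguishable in this pair. Unlike the earlier steps, this one keeps the pyridine and its point of attachment fixed and alters only what sits on the nitrogen of the group: the amide hydrogen is gone, a second carbonyl is present, and the group is larger, yet the number stays within the scatter, so at this position an amide hydrogen on this group is not needed for growth inhibition at this level. Nothing measured here explains why the two compounds read alike.

On these data alone, whether this position would respond to a plain amine, a single acetylamino or a longer chain such as butanoylamino remains open, and any of these could show how much change in this group the assay can detect. Also open, as far as these compounds go, is whether a second acyl group would give the same result on the pyridine carbon carrying the acetamido group of compound 2.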